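A few compounds are considered here, and "the series" means these few. Any claim that something is new, unique, unknown or untested is made for them only; others in the source may bear on it.

Compound 1 `CCCOc1nc2cccc(C(=O)O)c2n1Cc1ccc(-c2ccccc2-c2noc(O)n2)cc1` and compound 2 `CCSc1nc2cccc(C(=O)O)c2n1Cc1ccc(-c2ccccc2-c2noc(O)n2)cc1` share one core and differ at a single aromatic carbon. In a functional assay on the whole organism for inhibition, with Rattus norvegicus as the target, with a stated time of 7 h, at a dose of 1 mg/kg by the oral route (a higher number here means more inhibition at the dose given (going by the name of the read-out), a lower number less inhibition), compound 1 gives 100% and compound 2 gives 100%, so the step of no change at the digits printed from compound 1 to compound 2 (within the scatter) stays within the scatter. Compound 2 therefore stands level with compound 1 on the numbers at hand. Compound 3 `CCNc1nc2cccc(C(=O)O)c2n1Cc1ccc(-c2ccccc2-c2noc(O)n2)cc1` carries ethylamino in place of ethylsulfanyl on an aromatic carbon. Within the data shown here, only that one measured step bears on this change, and it was flat, so the step of a number 5 percentage points lower from compound 2 to compound 3 (within the scatter) is expected to stay within the scatter as well. The estimate for compound 3 is 95%, with a range from 80% to 100%.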

Compound 3, a percentage reported as inhibition, in the whole organism at one dose (the size of the read-out at that dose, not a potency): 6%
The estimate for compound 3 lay 89 percentage points above the measured number; the measured number lies below the stated range.
By their numbers in this assay, from the lowest: compound 3; then compounds 1 and 2 (each within the scatter of the next).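

At this aromatic carbon between two ring nitrogen atoms, the position proved far from indifferent in this assay: ethylamino in place of ethylsulfanyl gives a number 94 percentage points lower from compound 2 to compound 3 (beyond the scatter), and ethylamino in place of propoxy gives a number 94 percentage points lower from compound 1 to compound 3 (beyond the scatter). The flat step between the two earlier compounds therefore did not extend to ethylamino, so their match says nothing general about groups at this carbon. Nothing at hand accounts for the drop. The compounds shown leave open whether dimethylamino, which has no amine hydrogen, or a longer chain on the nitrogen would stay as low.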